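The source may report more compounds than this note shows. Statements on the series, on what has been measured and on what is new or still open speak of the compounds shown alone.

Working notes on the series.

Three compounds with the shared core have numbers in a functional assay on MCF7 cells (Homo sapiens) for cytotoxicity, read by MTT assay, with a stated time of 72 h; a higher number here means a weaker inhibitor, a lower number a stronger inhibitor. Compound 1 `O=C1c2c[n+]([O-])c3ccccc3c2C(=O)c2c1c1ccccc1n2Cc1cn([C@H]2C[C@H](O)[C@@H](CO)O2)nn1` gives 530 nM. Compound 2 `O=C1c2c[n+]([O-])c3ccccc3c2C(=O)c2c1c1ccccc1n2Cc1cn(C[C@@H](O)CO)nn1` gives 600 nM. Compound 3 `CC1(C)O[C@@H](CO)[C@H](Cn2cc(Cn3c4c(c5ccccc53)C(=O)c3c[n+]([O-])c5ccccc5c3C4=O)nn2)O1` gives 690 nM. Compound 3 has the highest of the three numbers, but every step to it lies within the scatter: a 1.3-fold higher number from compound 1 to compound 3 (0.11 log units; within the scatter) and a 1.2-fold higher number from compound 2 to compound 3 (0.06 log units; within the scatter), as does a 1.1-fold higher number from compound 1 to compound 2 (0.05 log units; within the scatter). The substituent on the aromatic nitrogen of the triazole has so far been swapped among a sugar-like ring, an open dihydroxypropyl chain and a protected dioxolane without any shift beyond the scatter.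

Compound 4 `CC1(C)OCC(Cn2cc(Cn3c4c(c5ccccc53)C(=O)c3c[n+]([O-])c5ccccc5c3C4=O)nn2)O1` follows from compound 3 by 2,2-dimethyl-1,3-dioxolan-4-yl in place of 5-(hydroxymethyl)-2,2-dimethyl-1,3-dioxolan-4-yl on a saturated chain carbon bound to an aromatic nitrogen. Within the data shown here, the steps that bear on it are the two that already touched this substituent, a 1.2-fold higher number from compound 2 to compound 3 (0.06 log units; within the scatter) and a 1.3-fold higher number from compound 1 to compound 3 (0.11 log units; within the scatter), both within the scatter. On that basis no step beyond the scatter is expected from compound 3 to compound 4 in this assay, and the expected step is a 1.1-fold higher number from compound 3 to compound 4 (0.04 log units; within the scatter). Compound 4 is estimated at 750 nM in this assay, with a range from 380 nM to 1500 nM.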

Compound 4, half-maximal inhibitory concentration: 290 nM
Compound 4: middle estimate off by 2.6-fold (0.41 log units), on the high side; measured number outside the range, below it.
By their numbers in this assay, from the lowest: compounds 4, 1, 2 and 3 (each within the scatter of the next, the first and the last beyond it).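

Among these compounds, the substituent on a saturated chain carbon bound to an aromatic nitrogen now gives the first steps beyond the scatter in this assay: 2,2-dimethyl-1,3-dioxolan-4-yl in place of 5-(hydroxymethyl)-2,2-dimethyl-1,3-dioxolan-4-yl gives a 2.4-fold lower number from compound 3 to compound 4 (0.38 log units; beyond the scatter) in a modest step, and the same group in place of 1,2-dihydroxyethyl gives a 2.1-fold lower number from compound 2 to compound 4 (0.32 log units; beyond the scatter), also modest. This position is therefore not as indifferent as the first three compounds suggested, although compound 1 goes against a clean separation: a 1.8-fold lower number from compound 1 to compound 4 (0.26 log units; within the scatter) stays within the scatter, so the 4-hydroxy-5-(hydroxymethyl)oxolan-2-yl compound cannot be told apart from compound 4 here. Nothing measured in the series accounts for the step seen on leaving the hydroxymethyl-bearing dioxolane.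

The compounds shown leave open whether the hydroxyl itself matters or the whole hydroxymethyl branch, which a methoxymethyl, aminomethyl or carboxylic acid group on the dioxolane would separate. Also open is how the two defined stereocentres of the leaving group bear on the number, since the entering group is shown with none defined.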